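From 4-Iodophenyl to 3-Fluorophenyl on the Amine Nitrogen

This account rests on a few compounds, and the source may have more. Where it says the series, first, only, none or still open, it means among the compounds named here.

Compound 1 `Cc1ccc(NC2=CC(=O)c3c(nc4n3[C@H]3OC[C@@H](O)[C@H]3OC4)C2=O)cc1`: 6590 nM
Compound 2 `O=C1C(Nc2ccc(I)cc2)=CC(=O)c2c1nc1n2[C@H]2OC[C@@H](O)[C@H]2OC1`: 4010 nM

Going by the values given here, in a functional assay on HeLa cells (Homo sapiens) for inhibition, read by sulforhodamine B assay (a lower number here means a stronger inhibitor, a higher number a weaker inhibitor), compound 2 holds the lower of the two numbers, and the single measured step, a 1.6-fold lower number from compound 1 to compound 2 (0.22 log units; within the scatter), lies within the scatter. Compound 3 `O=C1C(Nc2cccc(F)c2)=CC(=O)c2c1nc1n2[C@H]2OC[C@@H](O)[C@H]2OC1` differs from compound 2 by 3-fluorophenyl in place of 4-iodophenyl on an amine nitrogen. Among the compounds with values here, no measured step covers an exchange of this kind; the only step available exchanges one substituent on the same ring and stays within the scatter. Compound 3 is therefore expected to move no further than the scatter, as a 1.2-fold higher number from compound 2 to compound 3 (0.10 log units; within the scatter). Compound 3 is estimated at 5000 nM, within 2000 nM to 12000 nM.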

Compound 3, half-maximal inhibitory concentration: > 8000 nM
Compound 3 was reported as a limit (the forecaster's own chance of this, stated with the estimate: 5%); middle value at least 1.6-fold (0.20 log units) away from the limit.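

Compound 3 is reported only as a limit in this assay: the limit of > 8000 nM in this assay, at which 1 of the 3 values shown sits. With 3-fluorophenyl on the amine nitrogen, the series gives its first result without an exact number, so the steps can be read only as floors: an at least 1.9-fold higher number from compound 2 to compound 3 (0.29 log units; that floor lies within the scatter) and an at least 1.2-fold higher number from compound 1 to compound 3 (0.08 log units; that floor lies within the scatter). On these data alone, neither floor shows a change beyond the scatter, and the true size of either step stays unknown.

Compound 3 differs from compound 2 in both the halogen and its place on the ring, and the compounds shown do not separate the two. A 4-fluorophenyl or 3-iodophenyl group on the same nitrogen would address that question.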